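Cytotoxicity Limits Shared by Two Analogues, and a Nitrile Variant

The source may report more compounds than this note shows. Statements on the series, on what has been measured and on what is new or still open speak of the compounds shown alone.

Measured compounds:
compound 1, `COc1cc2c(cc1OC)[C@@H](C[C@@H](O)c1ccccc1)N(c1nc(=O)c3cc(C(F)(F)F)cc([N+](=O)[O-])c3s1)CC2`, > 85000 nM
compound 2, `CC(=O)c1ccc(N2CCN(c3nc(=O)c4cc(C(F)(F)F)cc([N+](=O)[O-])c4s3)CC2)cc1`, > 105000 nM

In a toxicity assay on HeLa cells (Homo sapiens) for cytotoxicity, read by colorimetric assay, with a stated time of 72 h (on this read-out lower numbers stand for higher toxicity in this test and higher numbers for lower toxicity in this test), compound 2 gives > 105000 nM, which is a limit of the assay and not a measured number. Compound 1 likewise gives only a limit, > 85000 nM. Both entries in this assay are therefore limits (the limit of > 105000 nM in this assay, at which 1 of the 2 values shown sits, (the limit of > 85000 nM in this assay, at which 1 of the 2 values shown sits)), so compound 2 cannot be ranked against compound 1 on these numbers; all that can be said is that neither compound showed measurable toxicity within the tested range.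

Compound 3, `N#Cc1cccc(N2CCN(c3nc(=O)c4cc(C(F)(F)F)cc([N+](=O)[O-])c4s3)CC2)c1`, differs from compound 2 in one place: 3-cyanophenyl in place of 4-acetylphenyl on an amine nitrogen in a ring. Among the compounds with values here, no step between two measured compounds exists here, and both measured values are limits, so there is no measured direction to build on. The expected step, an at least 1.0-fold lower number from compound 2 to compound 3 (0.02 log units; that floor lies within the scatter), is none beyond the usual scatter. Compound 3 is accordingly estimated at 100000 nM, with a range from 40000 nM to 250000 nM, and it is expected that this assay will most likely again report only a limit rather than a number.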

Compound 3, half-maximal cytotoxic concentration: > 108000 nM
Compound 3 was reported as a limit (the forecaster's own chance of this, stated with the estimate: 80%); middle value at least 1.0-fold (0.03 log units) from the limit.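

Compound 3, like compound 2, gives only a limit in this assay, so the step from compound 2 to compound 3 cannot be read: the limit of > 108000 nM in this assay, at which 1 of the 3 values shown sits.

The compounds shown leave open whether compound 1, compound 2 or compound 3 would give an actual number in this assay, and whether 3-cyanophenyl in place of 4-acetylphenyl changes that number.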